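This account rests on a few compounds, and the source may have more. Where it says the series, first, only, none or still open, it means among the compounds named here.

Measured in a functional assay on HEK293 cells for antagonist activity at Voltage-dependent L-type calcium channel subunit alpha-1D (Rattus norvegicus), read by FLIPR; on this read-out lower numbers stand for stronger inhibition and higher numbers for weaker inhibition:

Compound 1 `CCOC(=O)C1=C(C)NC(COC)=C(C(=O)OC)C1c1cccc([N+](=O)[O-])c1`: 96 nM
Compound 2 `C=CCOC(=O)C1=C(C)NC(C)=C(C(=O)OC)C1c1cccc([N+](=O)[O-])c1`: 15 nM
Compound 3 `C#CCCOC(=O)C1=C(C)NC(C)=C(C(=O)OC)C1c1cccc([N+](=O)[O-])c1`: 35 nM

All three compounds share one core and differ only in the groups hanging from it. Compound 3 stands second highest of the three numbers in this assay. Its nearest neighbour is compound 2, and the change from the one to the other is a single swap on the ester chain: a 2.3-fold higher number from compound 2 to compound 3 (0.37 log units; beyond the scatter). Compound 1 sits furthest away with a higher number, 96 nM, but it differs from compound 3 in a different place, so the two values can only be set side by side.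

Compound 4 `COC(=O)C1=C(C)NC(C)=C(C(=O)OCC2CC2)C1c1cccc([N+](=O)[O-])c1` is the next step from compound 3. The change is cyclopropyl in place of propargyl on a saturated chain carbon bound to an oxygen next to a carbonyl group. For the measured compounds named here, only one measured step touches this same place, the swap from vinyl to propargyl, and it was modest. Going by the values given here, no measured compound carries a small ring at this position, so there is nothing that speaks directly to the new group. The expectation for compound 4 is therefore a step of no more than the usual scatter in this assay, with no firm direction: a 1.2-fold lower number from compound 3 to compound 4 (0.07 log units; within the scatter). Compound 4 is estimated at 30 nM, within a range of 12 nM to 75 nM.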

Compound 4, half-maximal inhibitory concentration: 21 nM
The estimate for compound 4 lay 1.4-fold (0.15 log units) above the measured number; the measured number falls inside the stated range.
By their numbers in this assay, from the lowest: compounds 2, 4 and 3 (each within the scatter of the next, the first and the last beyond it); then compound 1.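

In this assay replacing propargyl with cyclopropyl on the ester chain gives a 1.7-fold lower number from compound 3 to compound 4 (0.22 log units; within the scatter) and replacing vinyl with cyclopropyl gives a 1.4-fold higher number from compound 2 to compound 4 (0.15 log units; within the scatter) so compound 4 cannot be told apart from either of its open-chain neighbours. For the compounds shown here, this is the first sign that a small carbon ring can sit on this saturated chain carbon bound to an oxygen next to a carbonyl group without a step beyond the scatter, even though compound 2 and compound 3 do differ by more than the scatter. No outside measurement is available to explain this result.

Going by these compounds alone, with only one ring here, it remains open whether the tolerance extends to a larger ring such as cyclobutyl or cyclohexyl, to a longer chain, or to a chain ending in an amine. Going by these compounds, compound 2, compound 3 and compound 4 also all keep the same methyl ester on the other side of the shared core, so it is unknown whether these chains would behave the same way with an ethyl ester or a benzyl ester there.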